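A few compounds are considered here, and "the series" means these few. Any claim that something is new, unique, unknown or untested is made for them only; others in the source may bear on it.

Of the compounds shown here, three share one core and have been measured in a functional assay on PC-3 cells (Homo sapiens) for cytotoxicity, read by MTT assay, with a stated time of 72 h; on this read-out higher numbers stand for weaker inhibition and lower numbers for stronger inhibition. Compound 1 `Nc1ccc(Nc2nc3ccccc3nc2S(=O)(=O)c2ccccc2)cc1` gives 5830 nM. Compound 2 `Cc1ccc(S(=O)(=O)c2nc3ccccc3nc2Nc2ccc(N)cc2)cc1` gives 5000 nM in this assay, and compound 3 `COc1ccc(S(=O)(=O)c2nc3ccccc3nc2Nc2ccc(N)cc2)cc1` gives 9640 nM. Compound 3 carries the highest of the three numbers, yet its gaps to the other two lie within the scatter: a 1.7-fold higher number from compound 1 to compound 3 (0.22 log units; within the scatter) and a 1.9-fold higher number from compound 2 to compound 3 (0.29 log units; within the scatter). The third measured step, a 1.2-fold lower number from compound 1 to compound 2 (0.07 log units; within the scatter), is likewise within the scatter. All three steps concern the ring that bears the methyl or methoxy, and none concerns the other outer ring.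

Compound 4 `COc1ccc(S(=O)(=O)c2nc3ccccc3nc2Nc2ccc(C(F)(F)F)cc2)cc1` differs from compound 3 on that other ring: trifluoromethyl in place of amino on an aromatic carbon. Within the data shown here, no measured step touches this position, so the three steps give no direction; they show only that another position tolerated methyl and methoxy without a change beyond the scatter. The step from compound 3 to compound 4 is therefore expected to be a 1.1-fold lower number from compound 3 to compound 4 (0.03 log units; within the scatter), carrying a wide uncertainty. Compound 4 is estimated at 9000 nM in this assay, within a range from 2500 nM to 35000 nM.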

Compound 4, half-maximal inhibitory concentration: 330 nM
Compound 4: the middle estimate sits 27-fold (1.44 log units) above what was measured; measured number below the stated range.
By their numbers in this assay, from the lowest: compound 4; then compounds 2, 1 and 3 (each within the scatter of the next).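

In this assay, the outer ring that carries the amino group proves to be a sensitive position: trifluoromethyl in place of amino gives a 29-fold lower number from compound 3 to compound 4 (1.47 log units; beyond the scatter). This is the only step shown that lies beyond the scatter, whereas the methyl and methoxy changes on the other outer ring all stayed within it. The compounds come with no information that would explain the size of this step.

Going by these compounds, this position rests on a single pair with a methoxy on the other ring, so it remains open whether the same change would give a step of similar size alongside the methyl of compound 2 or the unsubstituted ring of compound 1. Also open, on these data alone, is how a chlorine, a nitrile or a dimethylamino group at this place would compare with amino and trifluoromethyl.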